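The source may report more compounds than this note shows. Statements on the series, on what has been measured and on what is new or still open speak of the compounds shown alone.

Working notes on the series, read in a functional assay on NCI-H1993 cells (Homo sapiens) for inhibition, read by CCK-8 assay, with a stated time of 72 h; a higher number here means a weaker inhibitor, a lower number a stronger inhibitor. Compound 1 (`CC(c1c(F)cc2ncccc2c1F)n1cnc2ncc(-c3cnn(C)c3)nc21`) gives 35.5 nM, compound 2 (`CC(c1c(F)cc2ncccc2c1F)n1cnc2ncc(-c3ccccc3)nc21`) gives 514 nM, and compound 3 (`COC(=O)c1ccc(-c2cnc3ncn(C(C)c4cc5cccnc5cc4F)c3n2)cc1F`) gives 60.2 nM. The number for compound 3 lies within the scatter of that for compound 1 and well under that for compound 2.

Compound 4 (`COC(=O)c1ccc(-c2cnc3ncn(C(C)c4c(F)cc5ncccc5c4F)c3n2)cc1F`) differs from compound 3 by one change: fluoro in place of hydrogen on an aromatic carbon, ortho to a fused ring and ortho to a large group. Among the compounds with values here, the only measured step, a 14-fold higher number from compound 1 to compound 2 (1.16 log units; beyond the scatter), is large, but it is phenyl in place of 1-methyl-1H-pyrazol-4-yl, a different change. Within the data shown here, compounds 1 and 2 both carry this fluoro, yet no measured pair isolates it, so the data give no size for this step. No step beyond the scatter is therefore expected in this assay, in either direction. The expected shift is a 1.2-fold lower number from compound 3 to compound 4 (0.08 log units; within the scatter). For compound 4 the estimated value is 50 nM, with an expected range of 15 nM to 170 nM.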

Compound 4, half-maximal inhibitory concentration: 29.4 nM
The estimate for compound 4 lay 1.7-fold (0.23 log units) above the measured number, within the range that was stated.
By their numbers in this assay, from the lowest: compounds 4, 1 and 3 (each within the scatter of the next, the first and the last beyond it); then compound 2.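

In this assay, the step of a 2.0-fold lower number from compound 3 to compound 4 (0.31 log units; beyond the scatter) gives this fluoro, ortho to a fused ring and ortho to a large group, its first measured size, and that size is modest. With the fluoro held in place, 3-fluoro-4-(methoxycarbonyl)phenyl in place of phenyl gives a 17-fold lower number from compound 2 to compound 4 (1.24 log units; beyond the scatter) and is a large step, whereas the same group in place of 1-methyl-1H-pyrazol-4-yl gives a 1.2-fold lower number from compound 1 to compound 4 (0.08 log units; within the scatter) and so does not separate these two groups on the shared core. No measurement at hand offers a reason for these steps.

Within the data shown here, the fluoro step is read on only one pair, so its size with 1-methyl-1H-pyrazol-4-yl on the core remains open. Also open, on these data alone, is whether a carboxylic acid or an amide in place of the methoxycarbonyl group would keep the number of compound 4.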